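The source may report more compounds than this note shows. Statements on the series, on what has been measured and on what is new or still open speak of the compounds shown alone.

Measured in a functional assay on A549 cells (Homo sapiens) for cytotoxicity, read by MTT assay, with a stated time of 72 h; a higher number here means a weaker inhibitor, a lower number a stronger inhibitor:
- compound 1 `N#Cc1ccc(/C=C/C(=O)Nc2cc3c(Nc4ccc(F)c(Cl)c4)ncnc3cc2O[C@H]2CCOC2)cc1`: "not active" (no number reported)
- compound 2 `COc1ccc(/C=C/C(=O)Nc2cc3c(Nc4ccc(F)c(Cl)c4)ncnc3cc2OC)c(OC)c1`: 33300 nM
- compound 3 `COc1cc2ncnc(Nc3ccc(F)c(Cl)c3)c2cc1NC(=O)/C=C/c1ccc(C#N)cc1`: "not active" (no number reported)

Compound 1 has no single number in this assay: it is reported as "not active" (no number reported). Compound 3 is also without a number, reported as "not active" (no number reported). Among the compounds with values here, only compound 2 gives a number, at 33300 nM, so the series offers a single numerical reference point and no measured step.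

Next is compound 4 `O=C(/C=C/c1ccc(F)cc1Cl)Nc1cc2c(Nc3ccc(F)c(Cl)c3)ncnc2cc1O[C@H]1CCOC1`, which keeps the core of compound 1 and changes one group: 2-chloro-4-fluorophenyl in place of 4-cyanophenyl on a double-bonded chain carbon bound to a double-bonded chain carbon. In words, 2-chloro-4-fluorophenyl stands in place of 4-cyanophenyl on a double-bonded chain carbon bound to a double-bonded chain carbon.

With no number for compound 1, the step in this assay cannot be sized. At most a modest move toward the stronger side is expected, into the weak range marked by compound 2 at 33300 nM, and another result without a number remains quite possible. If a number is reported, compound 4 is expected at 30000 nM, within an estimated range of 10000 nM to 80000 nM.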

Compound 4, half-maximal inhibitory concentration: 5190 nM
The estimate for compound 4 lay 5.8-fold (0.76 log units) above the measured number; the whole stated range lies above it.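

Within the data shown here, compound 1 is reported as "not active" (no number reported) in this assay and compound 4 gives 5190 nM there, so no step between them can be read. The compounds shown leave open how large the change from 4-cyanophenyl to 2-chloro-4-fluorophenyl is. No measured evidence bears on this result.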